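The source may hold more compounds than are shown below. What is called first, only, known or untested is meant among the compounds shown, and "the series" means these compounds.

Measured compounds in this series:
compound 1, `CS/C(=N\C(=O)c1ccno1)NC(=O)c1ccno1`, > 100000 nM
compound 2, `O=C(/N=C(/NC(=O)c1ccno1)[Se]Cc1ccccc1)c1ccno1`, 94700 nM
compound 3, `O=C(/N=C(/NC(=O)c1cc(-c2ccccc2)nc2ccccc12)[Se]Cc1ccccc1)c1cc(-c2ccccc2)nc2ccccc12`, 88900 nM

All three were tested in a functional assay on K562 cells (Homo sapiens) for cytotoxicity, read by MTT assay, with a stated time of 72 h; on this read-out lower numbers stand for higher toxicity in this test and higher numbers for lower toxicity in this test. The value of compound 1 in this assay is a limit of the test and not a number. Compound 2 gives 94700 nM in this assay, and compound 3 gives 88900 nM; the two sit within the scatter of each other, so no order between them is claimed. The difference between the core of compound 2 and the core of compound 3 is not broken down here.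

One structural change is seen twice. From compound 2 to compound 1 it is a group of 2 heavy atoms (1 carbon, 1 sulfur; no ring) in place of a group of 8 heavy atoms (7 carbon, 1 selenium; one six-membered aromatic ring of carbon only), on a carbon with a double bond to nitrogen and it made an at least 1.0-fold higher number from compound 2 to compound 1 (0.02 log units; that floor lies within the scatter); that floor rests on (the limit of > 100000 nM in this assay, at which 1 of the 3 values shown sits), which only tells that compound 1 is not more toxic than compound 2 within reach of the test.

The not yet measured compound 4 is `CS/C(=N\C(=O)c1cc(-c2ccccc2)nc2ccccc12)NC(=O)c1cc(-c2ccccc2)nc2ccccc12`. It differs from compound 3 by a group of 2 heavy atoms (1 carbon, 1 sulfur; no ring) in place of a group of 8 heavy atoms (7 carbon, 1 selenium; one six-membered aromatic ring of carbon only), on a carbon with a double bond to nitrogen, the same change as from compound 2 to compound 1, at a place described in the same words. The step for compound 4 is expected to be a 1.3-fold higher number from compound 3 to compound 4 (0.13 log units; within the scatter), resting on the measured at least 1.0-fold higher number from compound 2 to compound 1 (0.02 log units; that floor lies within the scatter) and on (the limit of > 100000 nM in this assay, at which 1 of the 3 values shown sits). Compound 4 is thus expected to give about 120000 nM in this assay, with a plausible span from 70000 nM to 250000 nM, and there is a real chance that the test again reports only a limit.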

Compound 4, concentration lethal to 50% of the cells: > 100000 nM
Compound 4 ended at the assay's limit; the forecaster's own chance of this, stated with the estimate: 65%; the middle value lies beyond the limit too.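

In this assay compound 4 gives > 100000 nM, and this is a limit of the test and not a number. Putting methylsulfanyl in place of the group of 8 heavy atoms, on a carbon with a double bond to nitrogen whose other neighbours are two amide-type nitrogens, gives an at least 1.1-fold higher number from compound 3 to compound 4 (0.05 log units; that floor lies within the scatter), and set beside the earlier case the picture is this: the same change on two cores in this assay, an at least 1.0-fold higher number (0.02 log units; that floor lies within the scatter) from compound 2 to compound 1 and an at least 1.1-fold higher number (0.05 log units; that floor lies within the scatter) from compound 3 to compound 4; the limit leaves it open whether they differ On both cores the step therefore points the same way only as far as its floor can tell, and the change cannot be said to carry over with a given size, because the true number is missing for both methylsulfanyl compounds, with the test limit reached as follows: the limit of > 100000 nM in this assay, at which 2 of the 4 values shown sit.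

The compounds shown leave open how an amine or a longer chain would read in this assay on a carbon with a double bond to nitrogen, on either core. They also leave open whether any group in that place can move the number beyond the usual scatter, and whether such a step would keep its size from one core to the other.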